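Three Aryl Groups and a Benzofuran Still to Come

This account rests on a few compounds, and the source may have more. Where it says the series, first, only, none or still open, it means among the compounds named here.

Measured in an ADME assay on BJ cells (Homo sapiens), read by MTT assay, with a stated time of 72 h; on this read-out lower numbers stand for stronger inhibition and higher numbers for weaker inhibition:
- compound 1 `CNc1ncnc2c1c(-c1ccco1)cn2[C@@H]1O[C@H](CO)[C@@H](O)[C@H]1O`: 5040 nM
- compound 2 `CNc1ncnc2c1c(-c1cccs1)cn2[C@@H]1O[C@H](CO)[C@@H](O)[C@H]1O`: > 100000 nM (a limit)
- compound 3 `CNc1ncnc2c1c(-c1ccccc1)cn2[C@@H]1O[C@H](CO)[C@@H](O)[C@H]1O`: > 100000 nM (a limit)

In this assay compound 3 gives > 100000 nM, which is a limit of the assay and not a number. It sits at the limit of > 100000 nM in this assay, at which 2 of the 3 values shown sit.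

Compound 4 `CNc1ncnc2c1c(-c1cc3ccccc3o1)cn2[C@@H]1O[C@H](CO)[C@@H](O)[C@H]1O` differs from compound 3 in one place, where 1-benzofuran-2-yl stands in place of phenyl on an aromatic carbon: 1-benzofuran-2-yl in place of phenyl on an aromatic carbon.

Among the compounds with values here, two measured steps bear on this change, and both are large: an at least 19-fold higher number from compound 1 to compound 3 (1.29 log units; beyond the scatter), and an at least 19-fold higher number from compound 1 to compound 2 (1.29 log units; beyond the scatter). In both, the furan-2-yl group of compound 1 gives way to another group. The entering group also holds a five-membered aromatic ring with 1 hetero atom, but it is larger than furan-2-yl, so only a partial return towards compound 1 at 5040 nM is expected.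

The expected change is an at least 2.5-fold lower number from compound 3 to compound 4 (0.39 log units; beyond the scatter), towards stronger inhibition, though the assay may again report only a limit. The estimate for compound 4 is 40000 nM, with an expected range from 8000 nM to 100000 nM.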

Compound 4, half-maximal inhibitory concentration: 75600 nM
Estimate against measurement, compound 4: 1.9-fold (0.28 log units) below, and the stated range covers the measured number.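

In this assay, within the data shown here, compound 4 is the only compound besides compound 1 to give a number and not a limit with an aryl group at this aromatic carbon. Even so, the 1-benzofuran-2-yl group, which keeps a five-membered aromatic ring with 1 hetero atom, does not hold the level of furan-2-yl, as a 15-fold higher number from compound 1 to compound 4 (1.18 log units; beyond the scatter) shows. Against the other two groups the result gives only an at least 1.3-fold lower number from compound 3 to compound 4 (0.12 log units; that floor lies within the scatter) and an at least 1.3-fold lower number from compound 2 to compound 4 (0.12 log units; that floor lies within the scatter) so no gain over phenyl or thiophen-2-yl is established.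

From the compounds shown here alone, it stays open whether the lower number of compound 1 is tied to furan-2-yl itself, which a furan-3-yl or 5-methylfuran-2-yl group would test. How an amine or a carboxylic acid on the furan ring would shift the number is also unknown.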